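The source may hold more compounds than are shown below. What is called first, only, known or untested is meant among the compounds shown, and "the series" means these compounds.

Working notes on the series.

Compound 2 `Cn1cnnc1SCC(=O)Nc1ccc(-c2nc(-c3ccccc3)c(-c3ccccc3)n2C)cc1` is the stronger of the two measured compounds. Among the compounds with values here, in a functional assay on MCF7 cells (Homo sapiens) for cytotoxicity, read by MTT assay, with a stated time of 24 h, tested at 16 ug/mL (on this read-out higher numbers stand for a stronger effect at the one concentration tested and lower numbers for a weaker effect), compound 2 gives 61.2%, the highest of the two numbers so far. Within the data shown here, the nearest comparison is compound 1 `Cn1c(-c2ccc(NC(=O)CCl)cc2)nc(-c2ccccc2)c1-c1ccccc1`, which in this assay gives 15.2%; the one measured step, a number 46 percentage points higher from compound 1 to compound 2 (beyond the scatter), is large and lies beyond the scatter.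

The next compound, compound 3 `Cn1nnnc1SCC(=O)Nc1ccc(-c2nc(-c3ccccc3)c(-c3ccccc3)n2C)cc1`, differs from compound 2 in one place: 1-methyl-1H-tetrazol-5-yl in place of 4-methyl-4H-1,2,4-triazol-3-yl on a sulfur. Among the measured compounds shown here, the measured step from compound 1 to compound 2 exchanges chloro for the whole (4-methyl-4H-1,2,4-triazol-3-yl)sulfanyl group and so does not bear directly on a swap of one methylated five-membered ring for another on the sulfur; no measured pair shows this kind of change. With the sulfur-linked methylated ring retained, no step beyond the scatter is expected in this assay in either direction, and the expected step is a number 6.2 percentage points lower from compound 2 to compound 3 (within the scatter).

Compound 3 is therefore estimated at 55% in this assay, with the range 30% to 78% reflecting the absence of a directly comparable measured step.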

Compound 3, a percentage reported as activity, at one concentration (the size of the read-out at that concentration, not a potency): 63.7%
Compound 3: the middle estimate sits 8.7 percentage points below what was measured; measured number inside the range.
By their numbers in this assay, from the lowest: compound 1; then compounds 2 and 3 (each within the scatter of the next).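

In this assay, within the data shown here, the change on the sulfur is the first measured exchange that keeps a sulfur-linked methylated five-membered ring in place, and a number 2.5 percentage points higher from compound 2 to compound 3 (within the scatter) shows that 1-methyl-1H-tetrazol-5-yl and 4-methyl-4H-1,2,4-triazol-3-yl cannot be told apart on this read-out. Against the chloro compound, a number 48.5 percentage points higher from compound 1 to compound 3 (beyond the scatter) now stands beside a number 46 percentage points higher from compound 1 to compound 2 (beyond the scatter), so the large gain is seen with two different rings on the sulfur rather than with one. No measured evidence on the cause of these numbers is available.

The compounds shown leave open whether the gain depends on the ring, on the sulfur or on the replacement of chloro itself: an amine such as morpholine in place of chloro, or a carboxylic acid on the sulfur in place of the ring, would separate these possibilities. On these data alone, each number also describes the size of the effect at a single concentration, so how compound 2 and compound 3 compare at any other concentration remains open.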